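The source may report more compounds than this note shows. Statements on the series, on what has been measured and on what is new or still open speak of the compounds shown alone.

Compounds measured so far in a functional assay on the whole organism with Rattus norvegicus as the target, at a dose of 20 mg/kg by the oral route; a higher number here means more inhibition at the dose given (going by the name of the read-out), a lower number less inhibition:

- Compound 1, `CNC(=O)/C=C1\CCc2ccc(Br)cc21`: 53%
- Compound 2, `O=C(/C=C1\CCc2ccc(F)cc21)NCCO`: 78%
- Compound 3, `O=C(/C=C1\CCc2ccc(F)cc21)N1CCCC1`: 18%

All three share one core, a bicyclic ring bearing a halogen and an exocyclic double bond that carries an amide; they differ in the halogen and in the group on the amide. Compound 3 stands at the bottom of the three numbers: compound 2 lies well above it, with a number 60 percentage points lower from compound 2 to compound 3 (beyond the scatter) when pyrrolidin-1-yl replaces (2-hydroxyethyl)amino on the carbonyl carbon. Compound 1, with its methylamino amide and a bromine in place of fluorine, gives 53%, whereas compound 3 gives 18%, a gap also beyond the usual scatter.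

Compound 4, `CNC(=O)/C=C1\CCc2ccc(F)cc21`, has not been measured. It differs from compound 3 in one place: methylamino in place of pyrrolidin-1-yl on a carbonyl carbon. This largely undoes the change seen from compound 2 to compound 3, since an amide with a hydrogen donor returns, and compound 1 shows what the same methylamino amide gives on the bromine core. A large rise in this assay is therefore expected, with a number 37 percentage points higher from compound 3 to compound 4 (beyond the scatter) as the estimated step. Compound 4 is expected to give about 55%, within a range of 35% to 78%.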

Compound 4, a percentage reported as inhibition, in the whole organism at one dose (the size of the read-out at that dose, not a potency): 38%
Estimate against measurement, compound 4: 17 percentage points above; the measured number falls inside the stated range.
By their numbers in this assay, from the lowest: compound 3; then compound 4; then compound 1; then compound 2.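

In this assay, swapping the pyrrolidin-1-yl ring on the carbonyl carbon for methylamino gives a number 20 percentage points higher from compound 3 to compound 4 (beyond the scatter) on the fluorine core, so this position responds to the change, but the rise recovers only part of the gap to the 2-hydroxyethyl amide. That remaining gap is now seen directly, with a number 40 percentage points lower from compound 2 to compound 4 (beyond the scatter) when hydrogen replaces hydroxymethyl on the saturated chain carbon, which shows that the hydroxyl-bearing end of the chain matters in this series, beyond simply having a methylamino-type amide. Among these compounds, the halogen can also be read on its own for the first time, since the amide is held constant and a number 15 percentage points lower from compound 1 to compound 4 (beyond the scatter) when fluoro replaces bromo on the aromatic carbon. No measurement on hand explains why any of these steps has the size it does.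

The compounds shown leave open whether the hydroxyl group itself or the longer chain carries the advantage of compound 2, a question that an ethylamino amide on the fluorine core would separate. A dimethylamino amide would likewise help to show whether the low number of compound 3 belongs to its ring or to the missing amide hydrogen.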